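This account rests on a few compounds, and the source may have more. Where it says the series, first, only, none or still open, it means among the compounds named here.

Compound 2, `Cc1cc(O)c(C2=NN(c3ccc(S(N)(=O)=O)cc3)C(c3ccccc3Cl)C2)cc1Cl`, carries a 2-chlorophenyl group on a saturated ring carbon of the shared core. In a functional assay on MDA-MB-231 cells (Homo sapiens) for antiproliferative activity, with a stated time of 48 h (a higher number here means a weaker inhibitor of growth, a lower number a stronger inhibitor of growth), compound 2 gives 4520 nM. Among the two numbers measured so far this stands at the low end, the only neighbour being compound 1, `Cc1cc(O)c(C2=NN(c3ccc(S(N)(=O)=O)cc3)C(c3ccccc3O)C2)cc1Cl`, which in this assay gives 6690 nM. Among the compounds with values here, the single measured step, a 1.5-fold lower number from compound 1 to compound 2 (0.17 log units; within the scatter), exchanges a hydroxy for a chloro on that aromatic ring and lies within the scatter, so on these numbers the two compounds cannot be set in order.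

Compound 3, `Cc1cc(O)c(C2=NN(c3ccc(S(N)(=O)=O)cc3)C(/C=C/c3ccccc3)C2)cc1Cl`, is not yet measured. It differs from compound 2 by 2-phenylethenyl in place of 2-chlorophenyl on a saturated ring carbon. Within the data shown here, no measured step touches this position in the same way: the one step available, from compound 1 to compound 2, exchanges one small substituent on the same ring for another and moves the number very little. There is therefore no ground to expect a shift in this assay beyond the scatter in either direction, although replacing the whole 2-chlorophenyl by 2-phenylethenyl is a larger change than any yet tested, which widens the uncertainty. The estimate for compound 3 is 4500 nM, with a range from 1500 nM to 14000 nM. This expectation amounts to a step of a 1.0-fold lower number from compound 2 to compound 3 (0.00 log units; within the scatter).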

Compound 3, concentration for total growth inhibition: 16300 nM
Compound 3: the middle estimate sits 3.6-fold (0.56 log units) below what was measured; the whole stated range lies below it.
By their numbers in this assay, from the lowest: compounds 2 and 1 (each within the scatter of the next); then compound 3.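

Until now, the groups tried on this saturated ring carbon could not be told apart, but 2-phenylethenyl in this assay gives a 3.6-fold higher number from compound 2 to compound 3 (0.56 log units; beyond the scatter) and also a 2.4-fold higher number from compound 1 to compound 3 (0.39 log units; beyond the scatter), both modest and both beyond the scatter. The position therefore does respond to what it carries: compound 3 is a weaker inhibitor of growth than compound 1 or compound 2, which both have a substituted phenyl ring attached directly at this carbon. Nothing given here explains the shift.

The change alters several things at once, since it removes the chlorine and adds a double bond outside the aromatic ring, so these compounds cannot show which of these matters. Still open, from the compounds shown here alone, is how a plain phenyl, a saturated 2-phenylethyl chain or a 2-aminophenyl group would behave at this carbon, and any of these could help separate the effect of the double bond from that of the substituent on the ring.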